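Swapping Trifluoromethoxy for Methoxy: What Growth Inhibition to Expect

The compounds below may be only part of what the source reports. "The series", "measured", "known", "first", "only" and "open" are said of these compounds alone.

Among the compounds with values here, in a functional assay on KB cells (Homo sapiens) for inhibition, read by MTT assay, with a stated time of 24 h, tested at 100 ug/mL (a lower number here means less inhibition of growth, a higher number more inhibition of growth at the concentration tested), compound 1 `O=C(CCCCC(S)CCS)Nc1ccc(Cl)cc1` gives 44.1%, while compound 2 `O=C(CCCCC(S)CCS)Nc1ccc(OC(F)(F)F)cc1` gives 73.3%, the higher of the two numbers so far. Compound 3 `COc1ccc(NC(=O)CCCCC(S)CCS)cc1` differs from compound 2 in one place: methyl in place of trifluoromethyl on an oxygen on an aromatic ring. In other words, the trifluoromethoxy of compound 2 becomes methoxy in compound 3. Within the data shown here, no measured step makes this exact change. Among the measured compounds shown here, the only step available, trifluoromethoxy in place of chloro on an aromatic carbon, gives a number 29.2 percentage points higher from compound 1 to compound 2 (beyond the scatter). This single step is thin evidence, but it points to a lower number in this assay once trifluoromethoxy leaves, probably by somewhat less than that step. The estimated step is a number 21.3 percentage points lower from compound 2 to compound 3 (beyond the scatter). For compound 3, the expected value is 52%, with an estimated range of 30% to 72%.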

Compound 3, percent growth inhibition at one concentration: 22.2%
Compound 3: middle estimate off by 29.8 percentage points, on the high side, outside the stated range (below it).
By their numbers in this assay, from the lowest: compound 3; then compound 1; then compound 2.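

In this assay, within the data shown here, the change reaches much further than the one earlier step suggested: replacing trifluoromethyl with methyl on the oxygen gives a number 51.1 percentage points lower from compound 2 to compound 3 (beyond the scatter) and is the largest step seen so far. Methoxy also falls short of chloro, with a number 21.9 percentage points lower from compound 1 to compound 3 (beyond the scatter), so methoxy does not land between the other two groups, and a group's oxygen alone does not bring the higher number, since compound 2 and compound 3 both attach through oxygen. Nothing measured here explains this order.

As far as these compounds go, how a hydroxyl, an amine or a longer ethoxy group would compare in the same place remains open, so the three groups cannot yet be read as a trend. Readings at one concentration also leave open how these compounds would rank at other concentrations.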